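Bromo in place of trifluoromethyl: a one-point change

The compounds below may be only part of what the source reports. "The series", "measured", "known", "first", "only" and "open" are said of these compounds alone.

Measured so far:
compound 1, `C/C(=N\NC(=O)c1ccc(C(F)(F)F)cc1)c1cnccn1`: 2090 nM
compound 2, `C/C(=N\NC(=O)c1ccncc1)c1cnccn1`: 25200 nM

In an ADME assay on MRC5 cells (Homo sapiens) for antiproliferative activity, read by MTT assay (a higher number here means a weaker inhibitor, a lower number a stronger inhibitor), compound 1 gives 2090 nM, the lowest of the two numbers recorded. Going by the values given here, compound 2 gives 25200 nM, a far higher number, and that gap lies beyond the scatter, but the two compounds differ in more than one place and no single step is computed between them. Compound 3, `C/C(=N\NC(=O)c1ccc(Br)cc1)c1cnccn1`, has not yet been measured in this assay. It differs from compound 1 in one place: bromo in place of trifluoromethyl on an aromatic carbon. Among the compounds with values here, no measured pair shows what this change does, and no number here speaks for one group over the other. The step is therefore expected to stay within the scatter, leaning if anything toward a higher number: a 1.2-fold higher number from compound 1 to compound 3 (0.09 log units; within the scatter). For compound 3 the estimate in this assay is 2600 nM, with a range from 900 nM to 7500 nM.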

Compound 3, half-maximal inhibitory concentration: 2940 nM
For compound 3 the middle estimate is 1.1-fold (0.05 log units) below the measured one; the measured number falls inside the stated range.
By their numbers in this assay, from the lowest: compounds 1 and 3 (each within the scatter of the next); then compound 2.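

Bromo in place of trifluoromethyl on this aromatic carbon, para to a large group, gives in this assay a 1.4-fold higher number from compound 1 to compound 3 (0.15 log units; within the scatter) as the only single-place step among the compounds shown. At this position, one bromine atom and the four heavy atoms of trifluoromethyl therefore cannot be told apart in this read-out, so this site tolerates the exchange of these two groups without a difference beyond the usual scatter. Nothing on hand bears on why the two groups read alike.

From the compounds shown here alone, whether this tolerance extends to other kinds of group remains open, as an amine, a carboxylic acid or a methoxy group on the same carbon would be needed to test it. Also open, going by these compounds, is whether the same exchange reads alike when another part of the core differs.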